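Hydroxyphenyl replaces chlorophenyl on the shared core

This account rests on a few compounds, and the source may have more. Where it says the series, first, only, none or still open, it means among the compounds named here.

Compound 1 `COc1cccc(-c2ccc3ncn(-c4cc(OC)c(OC)c(OC)c4)c3c2)c1` gives 3310 nM in a functional assay on SGC-7901 cells (Homo sapiens) for antiproliferative activity, read by MTT assay, with a stated time of 72 h (on this read-out higher numbers stand for weaker inhibition and lower numbers for stronger inhibition), and compound 2 `COc1ccccc1-c1ccc2ncn(-c3cc(OC)c(OC)c(OC)c3)c2c1` gives 5050 nM. Compound 3 `COc1cc(-n2cnc3ccc(-c4ccccc4Cl)cc32)cc(OC)c1OC` gives only a limit of this assay, > 10000 nM. Compound 3 therefore stands at the limit of > 10000 nM in this assay, at which 1 of the 3 values shown sits, with an at least 3.0-fold higher number from compound 1 to compound 3 (0.48 log units; beyond the scatter) beyond the scatter and an at least 1.9-fold higher number from compound 2 to compound 3 (0.29 log units; that floor lies within the scatter) whose floor lies within it. Compound 4 `COc1cc(-n2cnc3ccc(-c4ccc(O)cc4)cc32)cc(OC)c1OC` carries 4-hydroxyphenyl in place of 2-chlorophenyl on an aromatic carbon. Among the compounds with values here, no measured step swaps 2-chlorophenyl for 4-hydroxyphenyl, so the expectation rests on the two steps that led into compound 3, both toward higher numbers, and on the values of compound 1 and compound 2. Compound 4 is expected to land near those two values, with an estimated 5000 nM and a range from 1500 nM to 20000 nM. That estimate means an expected at least 2.0-fold lower number from compound 3 to compound 4 (0.30 log units; that floor lies within the scatter), though a limit remains possible.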

Compound 4, half-maximal inhibitory concentration: > 10000 nM
Compound 4 was reported as a limit; the forecaster's own chance of this, stated with the estimate: 35%; middle value at least 2.0-fold (0.30 log units) away from the limit.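

In this assay compound 4 gives > 10000 nM, which is a limit and not a number. With 4-hydroxyphenyl, the group that brings a hydrogen-bond donor, this position shows an at least 3.0-fold higher number from compound 1 to compound 4 (0.48 log units; beyond the scatter), and also an at least 1.9-fold higher number from compound 2 to compound 4 (0.29 log units; that floor lies within the scatter). The step between compound 3 and compound 4 cannot be read: the limit of > 10000 nM in this assay, at which 2 of the 4 values shown sit.

The compounds shown do not separate the effect of the hydroxy group from that of its place on the ring. From the compounds shown here alone, how 4-methoxyphenyl or 4-aminophenyl would behave at this position remains open.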